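The source may report more compounds than this note shows. Statements on the series, on what has been measured and on what is new or still open speak of the compounds shown alone.

Of the compounds shown here, three that share one core have been tested in a functional assay on the whole organism (strain Swiss albino) with Mus musculus as the target, in the maximal electroshock model, with a stated time of 4 h; a lower number here means that less compound is needed, a higher number that more compound is needed for the effect. Compound 1 `COc1ccc(/C=N/NC(=O)Nc2cccc3ccccc23)cc1OC` gives 100 mg/kg in this assay. Compound 2 `COc1cccc(/C=N/NC(=O)Nc2cccc3ccccc23)c1` gives 300 mg/kg; the change was hydrogen in place of methoxy on an aromatic carbon, and a 3.0-fold higher number from compound 1 to compound 2 (0.48 log units; beyond the scatter). Compound 3 `O=C(N/N=C/c1ccc(Br)cc1)Nc1cccc2ccccc12` gives 300 mg/kg, and no change at the digits printed from compound 2 to compound 3 (within the scatter) with 4-bromophenyl in place of 3-methoxyphenyl on a carbon with a double bond to nitrogen. So compound 3 stands level with compound 2, the two together holding the highest numbers of the three, while compound 1 sits a modest step lower.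

Compound 4 `O=C(N/N=C/c1ccc(Cl)cc1)Nc1cccc2ccccc12` differs from compound 3 in one place: chloro in place of bromo on an aromatic carbon. For the measured compounds named here, no measured step swaps bromo for chloro; the nearest guide is the step from compound 2 to compound 3, where a bromo group entered and the number did not move beyond the scatter. A change this small is therefore expected to leave the number roughly where it is, so the expected step is no change at the digits printed from compound 3 to compound 4 (within the scatter). Compound 4 is thus estimated at 300 mg/kg, within a range from 100 mg/kg to 600 mg/kg.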

Compound 4, minimum effective dose: 300 mg/kg
Compound 4: middle estimate and measured number agree at the digits printed; measured number inside the range.
By their numbers in this assay, from the lowest: compound 1; then compounds 2, 3 and 4 (each within the scatter of the next).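

Chloro in place of bromo on this aromatic carbon gives no change at the digits printed from compound 3 to compound 4 (within the scatter) and so shows that, at this position, these two halogens cannot be told apart in this assay. Setting 4-chlorophenyl in place of 3-methoxyphenyl gives no change at the digits printed from compound 2 to compound 4 (within the scatter) and matches what the bromo compound showed, so a second halogen-bearing group now sits level with the single-methoxy compound. Nothing measured here explains why the number holds steady.

On these data alone, whether this position tolerates any group equally remains open, since a fluoro, an amine or a carboxylic acid in place of the chloro would test a much wider change. Also open, as far as these compounds go, is whether a methoxy added to the 4-chlorophenyl group would lower the number, as the step between compound 1 and compound 2 might suggest.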